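The compounds below may be only part of what the source reports. "The series", "measured", "known", "first", "only" and "open" are said of these compounds alone.

Measured in a functional assay on SiHa cells (Homo sapiens) for antiproliferative activity, read by CCK-8 assay, with a stated time of 72 h; a higher number here means a weaker inhibitor, a lower number a stronger inhibitor:
- compound 1 `COc1ccc(-c2cncnc2-c2cc(OC)c(OC)c(OC)c2)cc1F`: 3340 nM
- compound 2 `CCOc1ccc(-c2cncnc2-c2cc(OC)c(OC)c(OC)c2)cc1`: 640 nM

Of these two, compound 2 holds the lower number, 640 nM. Compound 3 `CCOc1ccc(-c2cncnc2-c2cc(OC)c(OC)c(OC)c2)cc1F` differs from compound 2 by one change, fluoro in place of hydrogen on an aromatic carbon. Going by the values given here, only one measured step bears on this, a 5.2-fold lower number from compound 1 to compound 2 (0.72 log units; beyond the scatter), and only in part, since it removes a fluoro but also exchanges methoxy for ethoxy. Some of that step may therefore be reversed in this assay, giving a higher number but a smaller step. The expected change is a 2.2-fold higher number from compound 2 to compound 3 (0.34 log units; beyond the scatter). For compound 3 the estimated value is 1400 nM, with an expected range of 450 nM to 4200 nM.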

Compound 3, half-maximal inhibitory concentration: 800 nM
Compound 3: the middle estimate sits 1.8-fold (0.24 log units) above what was measured, within the range that was stated.
By their numbers in this assay, from the lowest: compounds 2 and 3 (each within the scatter of the next); then compound 1.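

Fluoro in place of hydrogen ortho to an ethoxy group gives a 1.3-fold higher number from compound 2 to compound 3 (0.10 log units; within the scatter) in this assay and so leaves no difference that can be read at this place. With the fluoro held constant, methyl in place of hydrogen on the saturated chain carbon gives a 4.2-fold lower number from compound 1 to compound 3 (0.62 log units; beyond the scatter) and so ties the earlier gap to methoxy versus ethoxy, not to the fluoro. Nothing available explains either result.

On these data alone, whether chloro or an amine at this place would shift the number remains open. So does the effect of a longer chain, such as propoxy, in place of the ethoxy.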